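The source may report more compounds than this note shows. Statements on the series, on what has been measured and on what is new or still open speak of the compounds shown alone.

Measured so far in a functional assay on DU-145 cells (Homo sapiens) for antiproliferative activity, read by WST assay, with a stated time of 72 h; a higher number here means that more compound is needed for the effect, a lower number that less compound is needed
- Compound 1 `CCCCCCCC/C=C\c1c(C)cc(C)nc1CCCOC` gives > 30 uM as a limit of the assay, not a number
- Compound 2 `CCCCCCCCCCc1c(C)c(CCCCCCCCCC)c2[n+](c1C)CCC2` gives 1.3 uM
- Compound 3 `CCCCCCCC/C=C\c1c(C)c(/C=C\CCCCCCCC)c2[n+](c1C)CCC2` gives 1 uM

Compound 3, at 1 uM in this assay, lies within the usual scatter of compound 2. Compound 4 `CCCCCCCC/C=C/c1c(C)c(/C=C/CCCCCCCC)c2[n+](c1C)CCC2` has the same atoms and bonds as compound 3 and differs only in configuration as drawn (the two compounds have the same atoms and bonds and differ only in configuration as drawn: 2 of 2 stereo elements differ; a double bond is drawn Z in compound 3 and E in compound 4; a double bond is drawn Z in compound 3 and E in compound 4), with both double bonds drawn Z in compound 3 and E in compound 4. Going by the values given here, no measured pair shows what such a change does, so neither direction is favoured. The expected change is a 1.2-fold higher number from compound 3 to compound 4 (0.08 log units; within the scatter) and is not expected to exceed the scatter. For compound 4 the estimated value is 1.2 uM (expected range 0.5 uM to 3 uM).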

Compound 4, concentration for half-maximal effect: 0.8 uM
Compound 4: middle estimate off by 1.5-fold (0.18 log units), on the high side, within the range that was stated.
By their numbers in this assay, from the lowest: compounds 4, 3 and 2 (each within the scatter of the next). At a limit, above all of these: compound 1.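

In this assay, going by these compounds alone, the first measured change of configuration at these two double bonds is a 1.3-fold lower number from compound 3 to compound 4 (0.10 log units; within the scatter), so the two values stand within the scatter of each other. The step can be read as one of configuration alone: the fact that compounds 3 and 4 differ only in the configuration as drawn. Drawing both double bonds E rather than Z therefore gives a value of the same size in this pair.

The compounds shown leave open what either double bond does alone, as both differ together here. They also leave open how a longer chain, or a chain ending in a carboxylic acid or an amine, would read.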